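Cyclopropyl in place of ethyl: expectation for compound 4

The source may hold more compounds than are shown below. What is called first, only, known or untested is meant among the compounds shown, and "the series" means these compounds.

Of the compounds shown here, three have been measured in an ADME assay on microsomes from liver (Mus musculus) for metabolic stability, with a stated time of 10 min; a lower number here means that less of the compound is left, a higher number that more of the compound is left. Compound 1 `Cc1ccc(S(=O)(=O)[C@@]2(c3ccc(C(F)(C(F)(F)F)C(F)(F)F)cc3)CCN(C(=O)[C@H]3CC[C@H](C(=O)O)CC3)C2)cc1` gives 85%, compound 2 `CCc1ccc(S(=O)(=O)[C@@]2(c3ccc(C(F)(C(F)(F)F)C(F)(F)F)cc3)CCN(C(=O)[C@H]3CC[C@H](C(=O)O)CC3)C2)cc1` gives 100% and compound 3 `CCc1cc(S(=O)(=O)[C@@]2(c3ccc(C(F)(C(F)(F)F)C(F)(F)F)cc3)CCN(C(=O)[C@H]3CC[C@H](C(=O)O)CC3)C2)ccc1F` gives 73%. Compound 3 stands lowest of the three. The steps to it are modest but beyond the scatter: a number 12 percentage points lower from compound 1 to compound 3 (beyond the scatter) and a number 27 percentage points lower from compound 2 to compound 3 (beyond the scatter).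

Compound 4 `O=C(O)[C@H]1CC[C@H](C(=O)N2CC[C@](c3ccc(C(F)(C(F)(F)F)C(F)(F)F)cc3)(S(=O)(=O)c3ccc(F)c(C4CC4)c3)C2)CC1` carries cyclopropyl in place of ethyl on an aromatic carbon, ortho to a fluoro group and meta to a large group (cyclopropyl in place of ethyl on an aromatic carbon). Among the compounds with values here, no measured step makes this exchange. The nearest evidence is those two steps, together with a number 15 percentage points higher from compound 1 to compound 2 (beyond the scatter), which comes with methyl in place of hydrogen on a saturated chain carbon bound to an aromatic carbon. All three are modest, and none gives a direction for the new change. The expectation therefore starts from compound 3 at 73%. The expected step is a number 1 percentage points lower from compound 3 to compound 4 (within the scatter), within the scatter. For compound 4 the estimated value is 72%, with an expected range of 55% to 90%.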

Compound 4, percent of the compound remaining: 74%
The estimate for compound 4 lay 2 percentage points below the measured number; measured number inside the range.
By their numbers in this assay, from the lowest: compounds 3 and 4 (each within the scatter of the next); then compound 1; then compound 2.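

Swapping ethyl for cyclopropyl on this aromatic carbon, ortho to a fluoro group, gives in this assay a number 1 percentage points higher from compound 3 to compound 4 (within the scatter) and so shows no readable effect of the added ring at this place. Against the groups on the sulfonyl sulfur, 3-cyclopropyl-4-fluorophenyl in place of 4-ethylphenyl gives a number 26 percentage points lower from compound 2 to compound 4 (beyond the scatter) and in place of 4-methylphenyl gives a number 11 percentage points lower from compound 1 to compound 4 (beyond the scatter) and thus keeps the gap already seen with 3-ethyl-4-fluorophenyl. No measurement bearing on the reason for this outcome is available.

Going by these compounds, how a methoxy group or a longer chain such as propyl would behave on this aromatic carbon remains open. Also open, on these data alone, is how much of the gap to compound 2 belongs to the fluoro group and how much to where the alkyl group sits.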